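Carbonyl substituent swap, compound 3 to compound 4

The compounds below may be only part of what the source reports. "The series", "measured", "known", "first", "only" and "open" are said of these compounds alone.

Of the compounds shown here, three have been measured in an assay on isolated protein for inhibition of calcium/calmodulin-dependent protein kinase type II subunit alpha (Homo sapiens), read by HTRF, tested at 10 uM; a lower number here means less inhibition, a higher number more inhibition at the concentration tested (going by the name of the read-out). Compound 1 `COC[C@@H]1CCCN1C(=O)[C@@H]1CCCN1c1cc(Nc2cccc(OC)c2)nc(N)n1` gives 0% in this assay. Compound 2 `Cc1cccc(Oc2ccnc(N3CCC[C@H]3C(=O)NCCCn3ccnc3)n2)c1` gives 0% in this assay. Compound 3 `CN(CCCn1ccnc1)C(=O)[C@@H]1CCCN1c1nccc(Nc2ccccc2)n1` gives 0% in this assay. Compound 3 thus stands level with compounds 1 and 2 at the digits reported; the gap to compound 1 is no change within the scatter, and the gap to compound 2 is likewise no change within the scatter. Among the measured compounds shown here, no step between measured compounds that differ in one place is available in this set.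

Compound 4 `COC[C@@H]1CCCN1C(=O)[C@@H]1CCCN1c1nccc(Nc2ccccc2)n1` is the next compound to be measured in this assay. It differs from compound 3 in one place: 2-(methoxymethyl)pyrrolidin-1-yl in place of (3-(1H-imidazol-1-yl)propyl)(methyl)amino on a carbonyl carbon. The group that enters is the same group that sits on a carbonyl carbon in compound 1, and compound 1 gives 0% in this assay.

All three measured members show no inhibition at the digits reported, so the step of no change at the digits printed from compound 3 to compound 4 (within the scatter) is expected to be none beyond the scatter, in no particular direction. Compound 4 is estimated at 0% in this assay, with a range from -10% to 10%.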

Compound 4, a percentage reported as inhibition, at one concentration (the size of the read-out at that concentration, not a potency): 0%
Compound 4: the middle estimate sits on the measured number at the digits printed, and the stated range covers the measured number.
By their numbers in this assay, from the lowest: compounds 1, 2, 3 and 4 (each within the scatter of the next).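

In this assay, among the compounds shown here, the first readable step at this position, 2-(methoxymethyl)pyrrolidin-1-yl in place of (3-(1H-imidazol-1-yl)propyl)(methyl)amino on a carbonyl carbon, shows no change at the digits printed from compound 3 to compound 4 (within the scatter). Removing the imidazole ring and the open chain therefore brings no readable gain in inhibition at the concentration tested, but with both compounds at the bottom of the read-out, the step cannot show whether the position matters. No supporting measurement bears on this result.

Going by these compounds, it remains open whether any group on this carbonyl carbon, such as a carboxylic acid or a longer chain ending in a primary amine, would give measurable inhibition. A change elsewhere on the shared core, such as a chlorine on the phenyl ring of compound 4, is equally unresolved.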